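The source may report more compounds than this note shows. Statements on the series, on what has been measured and on what is new or still open speak of the compounds shown alone.

In an ADME assay on cells (Fibroblast, Homo sapiens) for cytotoxicity, with a stated time of 48 h (on this read-out higher numbers stand for weaker inhibition and lower numbers for stronger inhibition), compound 1 `COc1cccc(/C=C/C(=O)c2c(OC)cc(OC)cc2OC)c1` gives > 20000 nM, which is a limit of the assay and not a number. Compound 2 `COc1cc(OC)c(C(=O)/C=C/c2ccccc2)c(OC)c1` gives > 20000 nM, which is also a limit and not a number. Going by these compounds, the picture so far is therefore (the limit of > 20000 nM in this assay, at which 2 of the 2 values shown sit), so the true value of compound 2 remains unknown.

The next change leads to compound 3 `COc1cc(OC)c(C(=O)/C=C/c2ccc(F)cc2)c(OC)c1`: fluoro in place of hydrogen on an aromatic carbon. In words, this is fluoro in place of hydrogen on an aromatic carbon, which turns phenyl into 4-fluorophenyl. Among the measured compounds shown here, the only measured step that bears on this change is a step that the two limits leave unreadable from compound 1 to compound 2. That step also swaps a single group on an aromatic carbon, but it gives no size to carry over. No step beyond the usual scatter is therefore expected in this assay, and compound 3 is expected to be reported as a limit again. The expected step is a step that the limit leaves unreadable from compound 2 to compound 3. For compound 3 the estimated value is 22000 nM, with an expected range from 10000 nM to 45000 nM.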

Compound 3, half-maximal inhibitory concentration: > 20000 nM
Compound 3 gave a limit, no number; the forecaster's own chance of this, stated with the estimate: 75%; the middle value lies beyond the limit too.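

Among the compounds shown here, compound 3, like compound 1 and compound 2, is reported only as a limit of the assay and not as a number, so no step between these compounds can be read. The compounds shown leave open where the true values lie, and whether fluoro in place of hydrogen changes the read-out in this assay at all.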